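Swapping the aryl ring at the chain end of compound 1

This account rests on a few compounds, and the source may have more. Where it says the series, first, only, none or still open, it means among the compounds named here.

Measured compounds:
- compound 1, `CNC(=O)c1cc(Oc2ccc(C(=O)/C=C/c3ccc(F)cc3Cl)cc2)ccn1`: 21100 nM
- compound 2, `CNC(=O)c1cc(Oc2ccc(C(=O)/C=C/c3ccco3)cc2)ccn1`: "not determined" (no result reported)
- compound 3, `CNC(=O)c1cc(Oc2ccc(C(=O)/C=C/c3ccc(OC)cc3)cc2)ccn1`: "not determined" (no result reported)

Three compounds share one core and differ only in the aromatic ring at the far end of the double-bonded chain. Within the data shown here, in a functional assay on MCF7 cells (Homo sapiens) for cytotoxicity, read by MTT assay, with a stated time of 72 h (a lower number here means a stronger inhibitor, a higher number a weaker inhibitor), compound 1 gives 21100 nM, a weak result, and it is the only number in the set; compound 2 gives "not determined" (no result reported) and compound 3 gives "not determined" (no result reported), so nothing can be said about how the three compare.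

Compound 4, `CNC(=O)c1cc(Oc2ccc(C(=O)/C=C/c3ccc(Br)cc3)cc2)ccn1`, has not been measured. It differs from compound 1 in one place: 4-bromophenyl in place of 2-chloro-4-fluorophenyl on a double-bonded chain carbon bound to a double-bonded chain carbon. Among the measured compounds shown here, since no step between measured compounds exists here, there is no guide to how much such a swap moves the result in this assay. Compound 4 is therefore expected to stay close to compound 1, and the expected step is a 1.1-fold lower number from compound 1 to compound 4 (0.02 log units; within the scatter), none beyond the scatter. For compound 4 the estimate is 20000 nM, with a range from 7000 nM to 60000 nM.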

Compound 4, half-maximal inhibitory concentration: > 50000 nM
Compound 4: no number, only a limit; the forecaster's own chance of this, stated with the estimate: 20%; middle value at least 2.5-fold (0.39 log units) from the limit.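

Putting 4-bromophenyl in place of 2-chloro-4-fluorophenyl gives an at least 2.3-fold higher number from compound 1 to compound 4 (0.37 log units; beyond the scatter) in this assay, so the result at this position does depend on which aryl ring the chain carries. Compound 4 gives > 50000 nM, which is a limit of the assay and not a number. The step is therefore only a minimum, and its full size remains unknown, resting as it does on this limit: the limit of > 50000 nM in this assay, at which 1 of the 4 values shown sits.

The swap removes chlorine and fluorine and brings in bromine all at once, so these compounds cannot show which of those changes counts, and the steps involving compound 2 and compound 3 cannot be read. On these data alone, whether a plain phenyl ring, or a phenyl ring carrying an amine or a carboxylic acid, would give a lower number than compound 1 also stays open.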